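Chloro for bromo on the hydroxyphenyl group

The source may hold more compounds than are shown below. What is called first, only, known or untested is meant among the compounds shown, and "the series" means these compounds.

For the measured compounds named here, in a physicochemical assay for acid dissociation, using potentiometric titration, compound 1 `CCC/N=C1\S/C(=C\c2ccc(O)cc2)C(=O)N1c1ccccc1C` gives 8.3 and compound 2 `CCC/N=C1\S/C(=C\c2ccc(O)c(Br)c2)C(=O)N1c1ccccc1C` gives 6.4, the lower of the two numbers so far. Compound 3 `CCC/N=C1\S/C(=C\c2ccc(O)c(Cl)c2)C(=O)N1c1ccccc1C` has not yet been measured. It differs from compound 2 as follows: chloro in place of bromo on an aromatic carbon. In words, this is chloro in place of bromo on an aromatic carbon, ortho to a hydroxy group, so that 3-bromo-4-hydroxyphenyl becomes 3-chloro-4-hydroxyphenyl.

Going by the values given here, one measured step bears on this change: a number 1.90 log units lower from compound 1 to compound 2 (beyond the scatter), a large step for bromo in place of hydrogen on an aromatic carbon. Among the compounds with values here, it compares bromo with hydrogen, and no measured pair compares bromo with chloro, so the evidence is indirect. Compound 3 still carries a substituent where compound 1 has hydrogen, so its number is expected to lie close to that of compound 2 and not to return towards that of compound 1. The expected change in this assay is a number 0.10 log units higher from compound 2 to compound 3 (within the scatter), which would be no step beyond the scatter. The estimate for compound 3 is 6.5, with an expected range of 6.1 to 6.9.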

Compound 3, acid dissociation constant: 6.8
Compound 3: the middle estimate sits 0.30 log units below what was measured; low and high end bracket the measured number.
By their numbers in this assay, from the lowest: compound 2; then compound 3; then compound 1.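

In this assay, the two halogens are not interchangeable at this position, ortho to a hydroxy group: the change to chloro gives a number 0.40 log units higher from compound 2 to compound 3 (beyond the scatter), so the identity of the halogen matters as well as its presence. Chloro in place of hydrogen gives a number 1.50 log units lower from compound 1 to compound 3 (beyond the scatter), which places both halogen compounds clearly below compound 1 and shows that most of the shift seen in a number 1.90 log units lower from compound 1 to compound 2 (beyond the scatter) is kept with chloro. Nothing available here accounts for the difference between chloro and bromo.

Going by these compounds, it remains open where fluoro, iodo, a methyl group or a nitrile at this position would fall relative to hydrogen, chloro and bromo, and therefore whether the order of these three extends to other groups. On these data alone, it also remains open whether the steps seen here keep their size when a longer chain or a carboxylic acid is present elsewhere on the shared core.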